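Cyclopentyl in place of methyl on the amino nitrogen

A few compounds are considered here, and "the series" means these few. Any claim that something is new, unique, unknown or untested is made for them only; others in the source may bear on it.

Going by the values given here, compound 2 `CNc1ncc(-c2ccc(Oc3ccnc(-c4cnn(C)c4)c3)c(C)n2)c(=O)[nH]1` has the higher of the two numbers measured so far in a functional assay on NFS-60 cells (Mus musculus) for antiproliferative activity, read by resazurin assay, with a stated time of 72 h (on this read-out lower numbers stand for stronger inhibition and higher numbers for weaker inhibition), where compound 2 gives 1300 nM. Among the compounds with values here, its nearest relative, compound 1 `Cc1nc(-c2cnc(N(C)C)[nH]c2=O)ccc1Oc1ccnc(-c2cnn(C)c2)c1`, gives 716 nM in this assay, and the only measured step, a 1.8-fold higher number from compound 1 to compound 2 (0.26 log units; within the scatter), lies within the scatter. Compound 3 `Cc1nc(-c2cnc(NC3CCCC3)[nH]c2=O)ccc1Oc1ccnc(-c2cnn(C)c2)c1` has not yet been measured; the change from compound 2 is cyclopentyl in place of methyl on a nitrogen on an aromatic ring. Within the data shown here, the one step that bears on this place is a 1.8-fold higher number from compound 1 to compound 2 (0.26 log units; within the scatter). It alters the same nitrogen, and it was too small to count. Among the measured compounds shown here, no measured compound carries a ring on this nitrogen, so nothing speaks for a larger move. The step from compound 2 to compound 3 is therefore expected to stay within the scatter, a 1.3-fold lower number from compound 2 to compound 3 (0.11 log units; within the scatter). Compound 3 is estimated at 1000 nM in this assay, with a range from 300 nM to 4000 nM.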

Compound 3, half-maximal inhibitory concentration: 2.6 nM
Compound 3: the middle estimate sits 380-fold (2.59 log units) above what was measured; the measured number lies below the stated range.
By their numbers in this assay, from the lowest: compound 3; then compounds 1 and 2 (each within the scatter of the next).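

In this assay, going by these compounds alone, this amino nitrogen proves far more sensitive than the earlier compounds suggested: cyclopentyl in place of methyl gives a 500-fold lower number from compound 2 to compound 3 (2.70 log units; beyond the scatter), so the small step between the two compounds with methyl groups gave no hint of what a ring here could do. The comparison with the dimethylamino compound points the same way, with cyclopentylamino in place of dimethylamino giving a 280-fold lower number from compound 1 to compound 3 (2.44 log units; beyond the scatter), so the large change appears against both small amino groups. Nothing available here explains why this ring has so large an effect.

From the compounds shown here alone, whether the ring itself matters or simply a larger carbon group remains open, and an open pentyl chain on the same nitrogen would help separate the two. Also open, going by these compounds, is how much change this position tolerates, which cyclohexyl or an oxygen-containing tetrahydropyranyl ring would test.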